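This account rests on a few compounds, and the source may have more. Where it says the series, first, only, none or still open, it means among the compounds named here.

In an assay on HEK293 cells for agonist activity at transient receptor potential cation channel subfamily M member 8 (Homo sapiens), read by fluorescence and calcium flux, with a stated time of 15 min (on this read-out lower numbers stand for an effect already at smaller amounts and higher numbers for an effect only at larger amounts of compound), compound 1 `Cc1ccc(OCC(=O)N(Cc2cccs2)c2ccn(C)n2)cc1` gives 855 nM. Compound 2 `CCN(Cc1cccs1)C(=O)C(C)Oc1ccc(C)cc1` gives 889 nM in this assay, and since the two numbers lie within the usual scatter of each other, compound 1 cannot be set apart from compound 2 on the values shown. Compound 3 `Cc1ccc(OCC(=O)N(Cc2cccs2)c2nccs2)cc1` differs from compound 1 by 1,3-thiazol-2-yl in place of 1-methyl-1H-pyrazol-3-yl on an amide-type nitrogen. Within the data shown here, no measured pair shows what such a change does here. For compound 3 the expected step of a 1.0-fold lower number from compound 1 to compound 3 (0.00 log units; within the scatter) is therefore small, in no particular direction and not beyond the scatter. In this assay compound 3 is estimated at 850 nM, with a range from 280 nM to 2600 nM.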

Compound 3, half-maximal effective concentration: 2240 nM
Compound 3: the middle estimate sits 2.6-fold (0.42 log units) below what was measured, and the stated range covers the measured number.
By their numbers in this assay, from the lowest: compounds 1 and 2 (each within the scatter of the next); then compound 3.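

The group on the amide-type nitrogen is not interchangeable in this assay: 1,3-thiazol-2-yl in place of 1-methyl-1H-pyrazol-3-yl gives a 2.6-fold higher number from compound 1 to compound 3 (0.42 log units; beyond the scatter) as a modest step beyond the scatter. Both groups are five-membered aromatic rings with two hetero atoms and the same counted donors and acceptors, so that shared description does not settle the value at this position. Nothing measured here accounts for the step. From the compounds shown here alone, it remains open how a phenyl ring or a chain carrying an amine would fare on this nitrogen, and whether the step holds elsewhere on the shared core.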